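A few compounds are considered here, and "the series" means these few. Any claim that something is new, unique, unknown or untested is made for them only; others in the source may bear on it.

Measured compounds in a functional assay on HepG2 cells (Homo sapiens) for cytotoxicity, read by MTT assay, with a stated time of 48 h; a lower number here means a stronger inhibitor, a higher number a weaker inhibitor:
compound 1 `O=C(CSc1nnc(-c2ccncc2)o1)N/N=C/c1ccc([N+](=O)[O-])cc1` gives 17900 nM
compound 2 `Cc1ccc(/C=N/NC(=O)CSc2nnc(-c3ccncc3)o2)cc1` gives 10000 nM
compound 3 `O=C(CSc1nnc(-c2ccncc2)o1)N/N=C/c1cccc(C(F)(F)F)c1` gives 6520 nM

Compound 1 stands highest of the three numbers in this assay. Its nearest neighbour is compound 2, with a 1.8-fold lower number from compound 1 to compound 2 (0.25 log units; within the scatter), a step that stays within the scatter. Compound 3 lies furthest away; its value and that of compound 1 differ by more than the scatter, but no single change joins the two.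

Compound 4 `O=C(CSc1nnc(-c2ccncc2)o1)N/N=C/c1ccccc1[N+](=O)[O-]` keeps every atom of compound 1 and only rearranges the aryl group: 2-nitrophenyl in place of 4-nitrophenyl on a carbon with a double bond to nitrogen. For the measured compounds named here, none of the measured steps bears directly on this rearrangement. Going by the values given here, the one step from compound 1 to compound 2 exchanges nitro for methyl and remains within the scatter, which gives no sign that the nitro group, wherever it sits, moves the number far. Compound 4 is therefore expected to stay close to compound 1, with a 1.2-fold lower number from compound 1 to compound 4 (0.08 log units; within the scatter) expected to lie within the scatter. The estimate for compound 4 in this assay is 15000 nM, ranging from 6000 nM to 40000 nM.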

Compound 4, half-maximal inhibitory concentration: 24700 nM
Estimate against measurement, compound 4: 1.6-fold (0.22 log units) below; the measured number falls inside the stated range.
By their numbers in this assay, from the lowest: compounds 3, 2, 1 and 4 (each within the scatter of the next, the first and the last beyond it).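

In this assay, the exchange of 4-nitrophenyl for 2-nitrophenyl on a carbon with a double bond to nitrogen gives a 1.4-fold higher number from compound 1 to compound 4 (0.14 log units; within the scatter), so rearranging the same atoms at this place leaves the number inside the scatter. The exchange of 4-methylphenyl for 2-nitrophenyl gives a 2.5-fold higher number from compound 2 to compound 4 (0.39 log units; beyond the scatter), which passes beyond the scatter, whereas the exchange of 4-nitrophenyl for 4-methylphenyl, a 1.8-fold lower number from compound 1 to compound 2 (0.25 log units; within the scatter), does not. No accompanying measurement accounts for these numbers.

Going by these compounds, whether an amine or a carboxylic acid on this aryl group would move the number further remains open. Also open, on these data alone, is whether a change in the shared core, rather than in the aryl group, would shift the number more than any of these steps.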